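This account rests on a few compounds, and the source may have more. Where it says the series, first, only, none or still open, it means among the compounds named here.

Measured so far in a functional assay for inhibition, with Rattus norvegicus as the target, using microsomes; on this read-out lower numbers stand for stronger inhibition and higher numbers for weaker inhibition:
- compound 1, `COc1ccc2c(=O)cc(-c3ccc(O)c(O)c3)oc2c1`, gives 2500 nM
- compound 2, `C[N+](C)(C)CCCOc1ccc2c(=O)cc(-c3ccc(O)c(O)c3)oc2c1`, gives 37300 nM

For the measured compounds named here, compound 2 stands at the highest of the two numbers in this assay; its only neighbour is compound 1, whose number lies far lower. Going by the values given here, the one measured step, a 15-fold higher number from compound 1 to compound 2 (1.17 log units; beyond the scatter), came from putting a group of 6 heavy atoms in place of a hydrogen atom on a saturated chain carbon bound to an oxygen on an aromatic ring.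

Compound 3, `CN(C)CCCOc1ccc2c(=O)cc(-c3ccc(O)c(O)c3)oc2c1`, is the next member. It differs from compound 2 by a group of 3 heavy atoms (2 carbon, 1 nitrogen; no ring) in place of a group of 4 heavy atoms (3 carbon, 1 nitrogen; no ring), on a saturated chain carbon, three bonds along the chain from an oxygen on an aromatic ring. The step from compound 1 to compound 2 is the only one that bears on this change, and it was large. Compound 3 keeps the chain of compound 2 but not its charged group, so it sits between the two measured compounds in structure. A step of moderate size back toward the number of compound 1 is therefore expected, which is to say a lower number for compound 3 than for compound 2, a 4.7-fold lower number from compound 2 to compound 3 (0.67 log units; beyond the scatter). The estimate for compound 3 in this assay is 8000 nM, expected to fall between 2500 nM and 25000 nM.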

Compound 3, half-maximal inhibitory concentration: 8100 nM
Beside the measured number, compound 3's estimate is 1.0-fold (0.01 log units) below it; measured number inside the range.
By their numbers in this assay, from the lowest: compound 1; then compound 3; then compound 2.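

In this assay, putting dimethylamino, with no net charge, in place of the group with net charge +1, on a saturated chain carbon, three bonds along the chain from an oxygen on an aromatic ring, gives a 4.6-fold lower number from compound 2 to compound 3 (0.66 log units; beyond the scatter), so the group at the end of the chain matters at this place and not only the presence of the chain. The end group does not account for the whole of the earlier rise, however: the chain ending in dimethylamino still leaves a 3.2-fold higher number from compound 1 to compound 3 (0.51 log units; beyond the scatter), and the large step of a 15-fold higher number from compound 1 to compound 2 (1.17 log units; beyond the scatter) now appears as two parts, each beyond the scatter. The data shown offer no measured explanation for either part.

What the compounds shown leave open is whether a primary amine or a carboxylic acid at the end of the chain would bring the number closer to that of compound 1. They also leave open how a longer chain ending in dimethylamino would compare with compound 3, so the separate contribution of chain length cannot yet be judged.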